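Swapping the methoxyphenyl arm for a pyrimidine ring

This account rests on a few compounds, and the source may have more. Where it says the series, first, only, none or still open, it means among the compounds named here.

Compound 1 `COc1cccc(-c2c(C)nn(-c3nc(-c4ccc(Cl)c(Cl)c4)c(SC(C)C)s3)c2C(=O)O)c1`: 14000 nM
Compound 2 `COc1ccc(C)cc1-c1c(C)nn(-c2nc(-c3ccc(Cl)c(Cl)c3)c(SC(C)C)s2)c1C(=O)O`: 9500 nM
Compound 3 `COc1cncc(-c2c(C)nn(-c3nc(-c4ccc(Cl)c(Cl)c4)c(SC(C)C)s3)c2C(=O)O)c1`: 21000 nM

All three compounds share the same core and differ only in the aromatic ring attached to one carbon of that core. In a functional assay on BJAB cells (Homo sapiens) for antiproliferative activity, with a stated time of 4 days (on this read-out lower numbers stand for an effect already at smaller amounts and higher numbers for an effect only at larger amounts of compound), compound 1 gives 14000 nM, the second highest of the three numbers. Both of its steps to the neighbours, a 1.5-fold lower number from compound 1 to compound 2 (0.17 log units; within the scatter) and a 1.5-fold higher number from compound 1 to compound 3 (0.18 log units; within the scatter), lie within the scatter, so on these numbers compound 1 cannot be told apart from compound 2 or compound 3. Going by the values given here, only the step of a 2.2-fold higher number from compound 2 to compound 3 (0.34 log units; beyond the scatter) reaches beyond the scatter, and modestly.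

Compound 4 `Cc1nn(-c2nc(-c3ccc(Cl)c(Cl)c3)c(SC(C)C)s2)c(C(=O)O)c1-c1cncnc1` has not yet been measured. Its change from compound 1 is pyrimidin-5-yl in place of 3-methoxyphenyl on an aromatic carbon. The measured step that speaks most to this change is a 1.5-fold higher number from compound 1 to compound 3 (0.18 log units; within the scatter), in which a single ring nitrogen entered the same ring while the methoxy group stayed; it moved the number only within the scatter. Compound 4 goes further in the same direction, with two ring nitrogens entering and the methoxy group leaving, so a step toward higher numbers of similar or slightly larger size is expected, on the edge of the scatter. Compound 4 is therefore estimated to give 22000 nM, with a likely range from 9000 nM to 50000 nM. That estimate means a step of a 1.6-fold higher number from compound 1 to compound 4 (0.20 log units; within the scatter).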

Compound 4, half-maximal effective concentration: 22000 nM
Compound 4: middle estimate and measured number agree at the digits printed, within the range that was stated.
By their numbers in this assay, from the lowest: compounds 2, 1, 3 and 4 (each within the scatter of the next, the first and the last beyond it).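

Going from the methoxypyridine ring to the pyrimidin-5-yl ring adds a second ring nitrogen and removes the methoxy group, yet in this assay the step is a 1.0-fold higher number from compound 3 to compound 4 (0.02 log units; within the scatter) and leaves the two compounds indistinguishable, so on this read-out the methoxy group is not needed to keep the number where it is among these rings. The full swap from the carbon-only ring gives a 1.6-fold higher number from compound 1 to compound 4 (0.20 log units; within the scatter) and also stays inside the scatter, while the comparison with the methyl-bearing ring gives a 2.3-fold higher number from compound 2 to compound 4 (0.36 log units; beyond the scatter). Going by these compounds alone, only this last step and the earlier 2.2-fold higher number from compound 2 to compound 3 (0.34 log units; beyond the scatter) pass the scatter, with compound 1 within the scatter of both ends. The data shown offer no measurement that explains any of these steps.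

As far as these compounds go, every compound here carries a six-membered aromatic ring on this carbon, so it remains open whether an amine, a longer chain such as butyl, or a ring bearing a carboxylic acid would shift the number by more than these modest steps. All four numbers also come from a single cell assay, which leaves open how the same ring changes would read in any other test.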